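Same Atoms, Joined Differently: From Compound 1 to Compound 4

A few compounds are considered here, and "the series" means these few. Any claim that something is new, unique, unknown or untested is made for them only; others in the source may bear on it.

Compound 1 `N#Cc1ccc(N2CCC(C(=O)N3N=CC[C@H]3c3cc(F)cc(F)c3)CC2)nn1` was measured in a physicochemical assay for lipophilicity, read by HPLC, measured as chromatographic lipophilicity, at pH 7.4 (on this read-out lower numbers stand for lower lipophilicity and higher numbers for higher lipophilicity), where compound 1 gives 4.8. Among the three numbers known, that of compound 1 is the second highest. Its nearest neighbour is compound 3 `O=C(C1CCOCC1)N1N=CCC1c1ccccc1`, which in this assay gives 3.1, lower by more than the usual scatter. Furthest away lies compound 2 `CC(C)(C)C(=O)N1N=CCC1c1cccc(Cl)c1`, which gives 6.6, higher by more than the scatter. Compound 4 `N#Cc1cnc(N2CCC(C(=O)N3N=CC[C@H]3c3cc(F)cc(F)c3)CC2)cn1` contains the same atoms as compound 1, joined differently: a group of 8 heavy atoms (5 carbon, 3 nitrogen; one six-membered aromatic ring with 2 hetero atoms) in place of a group of 8 heavy atoms (5 carbon, 3 nitrogen; one six-membered aromatic ring with 2 hetero atoms), on an amine nitrogen in a ring. The group that enters is 5-cyanopyrazin-2-yl. Among the compounds with values here, no measured pair shows what such a change does here, so only a small step is expected, a number 0.20 log units higher from compound 1 to compound 4 (within the scatter), probably within the scatter. Compound 4 is therefore estimated at 5, between 4.5 and 5.5.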

Compound 4, distribution coefficient: 5.2
Estimate against measurement, compound 4: 0.20 log units below; the range from low to high includes it.
By their numbers in this assay, from the lowest: compound 3; then compound 1; then compound 4; then compound 2.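

In this assay, 5-cyanopyrazin-2-yl on the amine nitrogen in a ring gives a number 0.40 log units higher from compound 1 to compound 4 (beyond the scatter), so at this position a new arrangement of the same atoms is enough to move the read-out. Compound 2 and compound 3 differ from compound 1 in more than one place and could not show this. Nothing measured here accounts for the step. This single pair leaves open whether the step would recur on another core. It also leaves open what a carboxylic acid or a longer chain on the aromatic ring at this place would give.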